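A few compounds are considered here, and "the series" means these few. Any claim that something is new, unique, unknown or untested is made for them only; others in the source may bear on it.

Measured so far:
compound 1 `N#C/C(=C\N1CCN(C(=O)c2ccco2)C1=S)C(=O)Nc1ccc(Cl)cc1` — 15300 nM
compound 2 `N#C/C(=C\N1CCN(C(=O)c2ccco2)C1=S)C(N)=O` — 11000 nM

Two compounds of the series have been run in a functional assay on ACHN cells (Homo sapiens) for inhibition, read by sulforhodamine B assay, with a stated time of 48 h; a lower number here means a stronger inhibitor of growth, a higher number a weaker inhibitor of growth. Compound 1 gives 15300 nM and compound 2 gives 11000 nM. Going by the values given here, the single step, a 1.4-fold lower number from compound 1 to compound 2 (0.14 log units; within the scatter), is the only measured comparison in the set. Compound 2 thus holds the lowest of the two numbers, but its gap to compound 1 is within the scatter, so no order between the two can be claimed.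

Compound 3 `N#C/C(=C\N1CCN(C(=O)c2ccco2)C1=S)C(=O)c1ccccc1` is not yet measured. Its difference from compound 2 is phenyl in place of amino on a carbonyl carbon; cut one bond further out, this reads carbamoyl to benzoyl. Among the compounds with values here, no measured step changes the carbonyl carbon itself; the nearest comparison is the step at the amide-type nitrogen, which stayed within the scatter even though a ring was removed there. On that basis the expected step of a 1.1-fold higher number from compound 2 to compound 3 (0.04 log units; within the scatter) is none beyond the scatter, in no stated direction. Compound 3 is therefore expected to give about 12000 nM in this assay, with a range of 4000 nM to 40000 nM.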

Compound 3, concentration for 50% growth inhibition: 16600 nM
The estimate for compound 3 lay 1.4-fold (0.14 log units) below the measured number; measured number inside the range.
By their numbers in this assay, from the lowest: compounds 2, 1 and 3 (each within the scatter of the next).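

In this assay, phenyl in place of amino on the carbonyl carbon gives a 1.5-fold higher number from compound 2 to compound 3 (0.18 log units; within the scatter) and phenyl in place of (4-chlorophenyl)amino at the same carbon gives a 1.1-fold higher number from compound 1 to compound 3 (0.04 log units; within the scatter) in this three-compound set. Going by these compounds alone, the earlier step changed only the group on the amide-type nitrogen, whereas these steps remove that nitrogen altogether, and with the amino group a hydrogen-bond donor leaves, yet neither step lies beyond the scatter, so compounds 1, 2 and 3 cannot be ordered and no measured step here shows the nitrogen to matter for the number in this assay. No supporting data bear on this result.

The compounds shown leave open whether any group on this carbonyl carbon can give a step beyond the scatter, for example a hydroxyl, which would make a carboxylic acid, or a dimethylamino group. Since all three compounds share the rest of the structure, they also leave open whether changes elsewhere on the shared core would shift the number in this assay by more than the scatter.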